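A few compounds are considered here, and "the series" means these few. Any claim that something is new, unique, unknown or untested is made for them only; others in the source may bear on it.

The series shares one core: compound 1 `Oc1ccccc1CNc1ccc(-c2ccc(F)cc2)cc1`, compound 2 `CC(C)(C)c1ccc(-c2ccc(NCc3ccccc3O)cc2)cc1`, compound 3 `Oc1ccccc1CNc1ccc(-c2ccc(-c3ccccc3)cc2)cc1` and the still unmeasured compound 4 `COc1ccc(-c2ccc(NCc3ccccc3O)cc2)cc1` differ from one another in a single group. In a functional assay on Jurkat cells (Homo sapiens) for activation, with a stated time of 24 h (a lower number here means that less compound is needed, a higher number that more compound is needed for the effect), compound 1 gives 3860 nM. In this assay compound 2 is reported as "not active" (no number reported). In this assay compound 3 likewise stands at "not active" (no number reported), so no number places it against compound 1; two of the three measured compounds return no value at all, and only compound 1 has given a number. The change from compound 3 to compound 4 is methoxy in place of phenyl on an aromatic carbon. Among the measured compounds shown here, no measured pair in this set shows a step of this kind, so its size cannot be read from the numbers and its direction stays open. The expectation for compound 4 in this assay is 5000 nM, with a range from 1500 nM to 20000 nM. A sizeable chance remains that, as for compound 3, no number is returned.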

Compound 4, half-maximal effective concentration: 580 nM
For compound 4 the middle estimate is 8.6-fold (0.94 log units) above the measured one, and the stated range ends above it.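

In this assay, this place on the aromatic ring, para to a large group, proves able to carry a substituent that gives a clear number: compound 4 reaches 580 nM, whereas compound 3, with phenyl there, is reported as "not active". Among the compounds that give a number, methoxy in place of fluoro yields a 6.7-fold lower number from compound 1 to compound 4 (0.82 log units; beyond the scatter), the first measured step at this place, and it shows that the response depends on which group sits there. No measurement on hand explains this difference.

The compounds shown leave open whether the step is particular to methoxy or would extend to an ethoxy or an amine at the same place. They also leave open whether the methoxy result would hold with a change elsewhere on the shared core.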